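Two Measured Analogues and One Untested Dihydroxy Relative

This account rests on a few compounds, and the source may have more. Where it says the series, first, only, none or still open, it means among the compounds named here.

Compound 1 `COc1ccc(OC)c(-c2cc(-c3ccccc3)nn2-c2ccc(S(N)(=O)=O)cc2)c1`: 43700 nM
Compound 2 `COc1ccc(OC)c(-c2cc(-c3ccccc3)nn2-c2ccc(S(=O)(=O)NC(C)=O)cc2)c1`: 50700 nM

Both measured compounds were tested in a functional assay on cells (Cancer cell lines, Homo sapiens) for cytotoxicity, read by sulforhodamine B assay, with a stated time of 48 h; a lower number here means a stronger inhibitor of growth, a higher number a weaker inhibitor of growth. Compound 2 holds the higher of the two numbers, yet the step of a 1.2-fold higher number from compound 1 to compound 2 (0.06 log units; within the scatter) lies within the scatter, so on these data the two compounds cannot be told apart; the acetyl on the sulfonamide nitrogen made no visible difference.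

Compound 3 `CC(=O)NS(=O)(=O)c1ccc(-n2nc(-c3ccccc3)cc2-c2cc(O)ccc2O)cc1` has not yet been measured. It differs from compound 2 in one place: 2,5-dihydroxyphenyl in place of 2,5-dimethoxyphenyl on an aromatic carbon. Among the measured compounds shown here, no measured step bears on this change. For the measured compounds named here, the single known step concerns the sulfonamide nitrogen, a different part of the molecule, and was itself within the scatter, so it offers no guide to what removing the two methyl groups from the oxygens will do. The expectation for compound 3 therefore rests almost entirely on the value of compound 2 and carries a wide range in both directions. The expected step is a 1.4-fold lower number from compound 2 to compound 3 (0.16 log units; within the scatter), a modest move toward a lower number. Compound 3 is estimated at 35000 nM, with a likely range from 12000 nM to 100000 nM.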

Compound 3, concentration for total growth inhibition: 100000 nM
Compound 3: the middle estimate sits 2.9-fold (0.46 log units) below what was measured, within the range that was stated.
By their numbers in this assay, from the lowest: compounds 1, 2 and 3 (each within the scatter of the next, the first and the last beyond it).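

Among the compounds shown here, the earlier step spoke only of the sulfonamide nitrogen, so this is the first reading at the aromatic carbon of the five-membered ring, where 2,5-dihydroxyphenyl in place of 2,5-dimethoxyphenyl gives a 2.0-fold higher number from compound 2 to compound 3 (0.29 log units; within the scatter) in this assay on the shared core. The change removes the methyl groups from the oxygens and goes from 0 hydrogen-bond donors to 2 hydrogen-bond donors, yet compound 2 and compound 3 still cannot be told apart, so at this position the two groups are not distinguished by these data. No measurement of any property of these compounds is available to account for this outcome.

Going by these compounds, it remains open whether an amine or a carboxylic acid on this phenyl ring, or a longer chain such as propoxy on its oxygens, would move the number beyond the scatter. On these data alone, it is also open whether the same exchange would read alike with hydrogen in place of acetyl on the sulfonamide nitrogen, as in compound 1.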